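Swapping methyl for chloro on the shared core

This account rests on a few compounds, and the source may have more. Where it says the series, first, only, none or still open, it means among the compounds named here.

compound 1 `CONC(=S)N/N=C1\C(=O)N(CN2CCN(c3ccc(Cl)cc3)CC2)c2ccc(Cl)cc21` gives 229000 nM
compound 2 `CONC(=S)N/N=C1\C(=O)N(CN2CCN(c3ccccc3)CC2)c2ccc(C)cc21` gives 276000 nM

These two results come from an ADME assay on MT4 cells (Homo sapiens) for cytotoxicity, read by spectrophotometry, with a stated time of 5 days (a higher number here means that more compound is tolerated, a lower number that less compound is tolerated), and they lie within the usual scatter of each other. Going by the values given here, compound 2 therefore stands level with compound 1 on the numbers so far, and neither can be separated from the other.

Compound 3 `CONC(=S)N/N=C1\C(=O)N(CN2CCN(c3ccccc3)CC2)c2ccc(Cl)cc21` has not yet been measured. It departs from compound 2 in one place, with chloro in place of methyl on an aromatic carbon is the whole difference. Among the compounds with values here, no measured pair shows this exchange, so the data give no direct guide to it. In this assay no change beyond the scatter is expected, and no direction is favoured. The expected 1.1-fold lower number from compound 2 to compound 3 (0.04 log units; within the scatter) is accordingly small. The estimate for compound 3 is 250000 nM with an expected range from 130000 nM to 420000 nM in this read-out.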

Compound 3, half-maximal cytotoxic concentration: 267000 nM
For compound 3 the middle estimate is 1.1-fold (0.03 log units) below the measured one, within the range that was stated.
By their numbers in this assay, from the lowest: compounds 1, 3 and 2 (each within the scatter of the next).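

In this assay the exchange of methyl for chloro on an aromatic carbon of the fused system gives a 1.0-fold lower number from compound 2 to compound 3 (0.01 log units; within the scatter), so at this position compound 2 and compound 3 cannot be told apart. Compound 3 also provides a second one-place comparison, with hydrogen in place of chloro on an aromatic carbon, which gives a 1.2-fold higher number from compound 1 to compound 3 (0.07 log units; within the scatter) and so separates neither compound from the other. Nothing measured here offers an explanation for either result.

From the compounds shown here alone, all three compounds carry only hydrogen, methyl or chloro at these two places, so the reach of this flat picture remains unknown. Going by these compounds, whether an amine, a carboxylic acid or a longer alkyl chain on the same aromatic carbon would give a number beyond the scatter stays open.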